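A few compounds are considered here, and "the series" means these few. Any claim that something is new, unique, unknown or untested is made for them only; others in the source may bear on it.

Compound 2 `CC(C)C[C@H](NC(=O)[C@H]1CSCN1)C(=O)N1CCC[C@H]1C(N)=O` stands lowest of the two numbers in hand: in a functional assay on the whole organism with Rattus norvegicus as the target, at a dose of 80 mg/kg (on this read-out lower numbers stand for less inhibition and higher numbers for more inhibition at the one dose given (going by the name of the read-out)), compound 2 gives 0%, while compound 1 `CC(C)C[C@H](NC(=O)[C@@H]1CNC(=O)N1)C(=O)N1CCC[C@H]1C(N)=O` gives 40% in this assay. Among the measured compounds shown here, the one measured step, a number 40 percentage points lower from compound 1 to compound 2 (beyond the scatter), exchanged the ring on the carbonyl carbon. Compound 3 `CC(C)C[C@H](NC(=O)[C@@H]1CCCN1)C(=O)N1CCC[C@H]1C(N)=O` alters the same place once more: a group of 5 heavy atoms (4 carbon, 1 nitrogen; one five-membered non-aromatic ring with 1 hetero atom) in place of a group of 5 heavy atoms (3 carbon, 1 nitrogen, 1 sulfur; one five-membered non-aromatic ring with 2 hetero atoms), on a carbonyl carbon. For the measured compounds named here, only the step from compound 1 to compound 2 bears on this, and it shows that an exchange of the ring on that carbonyl carbon can move the read-out by a large amount, yet it does not show which way a pyrrolidin-2-yl ring moves it. Compound 3 is therefore expected to fall between the two measured compounds, with the step of a number 20 percentage points higher from compound 2 to compound 3 (beyond the scatter) expected to be upward but uncertain. The estimate for compound 3 in this assay is 20%, within a range of 0% to 50%.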

Compound 3, a percentage reported as inhibition, in the whole organism at one dose (the size of the read-out at that dose, not a potency): 0%
Beside the measured number, compound 3's estimate is 20 percentage points above it; measured number inside the range.
By their numbers in this assay, from the lowest: compounds 2 and 3 (each within the scatter of the next); then compound 1.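

In this assay the exchange on the carbonyl carbon whose other neighbour is an amide-type nitrogen gives no change at the digits printed from compound 2 to compound 3 (within the scatter) when pyrrolidin-2-yl enters in place of the sulfur-containing ring, so these two rings are not told apart at this dose. The further step, a number 40 percentage points lower from compound 1 to compound 3 (beyond the scatter), shows that the large drop seen with compound 2 is not tied to sulfur, since a ring without sulfur stands at the same distance from compound 1. Among the three compounds, only the ring of compound 1 gives a read-out beyond the scatter of the other two. Nothing given here bears on why these rings read as they do. Open remains whether a 5-oxopyrrolidin-2-yl ring, a piperidin-2-yl ring or an open-chain amine on that carbonyl carbon would match compound 1, and whether other doses would separate compound 2 and compound 3.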